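A few compounds are considered here, and "the series" means these few. Any claim that something is new, unique, unknown or untested is made for them only; others in the source may bear on it.

Series notes, a functional assay on A549 cells (Homo sapiens) for cytotoxicity, read by resazurin assay, with a stated time of 72 h; on this read-out higher numbers stand for weaker inhibition and lower numbers for stronger inhibition:
compound 1 `C#Cn1ccnc1C#Cc1ccc(OC)cc1` gives 500 nM;
compound 2 `C#Cn1ccnc1C#Cc1ccc(C(F)(F)F)cc1` gives 6000 nM;
compound 3 `C#Cc1nc(-c2ccccc2)cn1C#C` gives 2500 nM.

Compound 3 stands second highest of the three numbers: compound 2 gives a higher number, compound 1 a lower one. Compound 4 `C#Cc1nc(-c2ccc(F)cc2)cn1C#C` differs from compound 3 by fluoro in place of hydrogen on an aromatic carbon. For the measured compounds named here, no measured step exchanges hydrogen for fluoro. Going by the values given here, the only counted step, a 12-fold higher number from compound 1 to compound 2 (1.08 log units; beyond the scatter), shows that swapping the group on the six-membered aromatic ring can shift the number a great deal, but it compares two larger groups and gives no direction for fluoro. The step expected is no change at the digits printed from compound 3 to compound 4 (within the scatter), not beyond the scatter. Compound 4 is therefore estimated at 2500 nM, range 1000 nM to 6000 nM.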

Compound 4, half-maximal inhibitory concentration: 2600 nM
Compound 4: middle estimate off by 1.0-fold (0.02 log units), on the low side, and the stated range covers the measured number.
By their numbers in this assay, from the lowest: compound 1; then compounds 3 and 4 (each within the scatter of the next); then compound 2.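

In this assay, for the compounds shown here, the exchange of hydrogen for fluoro gives a 1.0-fold higher number from compound 3 to compound 4 (0.02 log units; within the scatter) and so marks the first step on the core of compound 3. This position, on the six-membered aromatic ring of carbon only, takes a single fluorine atom with no change beyond the scatter, so the shift seen between methoxy and trifluoromethyl on the other core does not appear with this smaller exchange. Nothing measured accounts for this result.

Going by these compounds, whether methoxy or trifluoromethyl would act on the core of compound 3 as on the core of compound 1 stays open. So does the effect of an amine or a carboxylic acid at this position.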